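The source may report more compounds than this note shows. Statements on the series, on what has been measured and on what is new or still open speak of the compounds shown alone.

Compound 1, `COc1ccc(Cn2c(=O)n(C3OC(CO)[C@@H](O)[C@H]3O)c3nc(N)nc(O)c32)cc1`: 14%
Compound 2, `C=CCn1c(=S)n(C2OC(COC(C)=O)[C@H]3OC(C)(C)O[C@@H]23)c2nc(N)nc(O)c21`: 20%
Compound 3, `C=CCn1c(=O)n([C@@H]2O[C@H](CO)[C@H]3OC(C)(CCC(=O)OCC)O[C@H]32)c2nc(N)nc(O)c21`: 0%

In a functional assay on the whole organism with Mus musculus as the target (on this read-out higher numbers stand for larger maximal responses and lower numbers for smaller maximal responses), compound 3 gives 0%, the lowest of the three numbers. Compound 1, with 14%, stands nearest to it, and the gap between the two lies beyond the scatter. Compound 2, with 20%, stands furthest from compound 3, again beyond the scatter. The two measured neighbours of compound 3 differ from it in more than one place, so none of these gaps can be read as the effect of a single change.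

Compound 4, `C=CCn1c(=O)n([C@@H]2O[C@H](CO)[C@H]3OC(C)(CCC(=O)NC)O[C@H]32)c2nc(N)nc(O)c21`, differs from compound 3 in one place: methylamino in place of ethoxy on a carbonyl carbon. No pair of measured compounds shares this change, so the numbers shown give no direct guide to its effect. Compound 3 cannot move lower because it already gives 0%, and a large rise has no support in the shown compounds. The step of a number 5 percentage points higher from compound 3 to compound 4 (within the scatter) is therefore expected to stay within the scatter, with at most a slight upward drift. Compound 4 is estimated at 5%, in a range from 0% to 18%.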

Compound 4, largest response reached (reported as maximal response), in percent of the reference or control that the assay uses: 0%
Compound 4: middle estimate off by 5 percentage points, on the high side; the range from low to high includes it.
By their numbers in this assay, from the lowest: compounds 3 and 4 (each within the scatter of the next); then compounds 1 and 2 (each within the scatter of the next).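

In this assay, going by these compounds alone, methylamino in place of ethoxy on a carbonyl carbon gives no change at the digits printed from compound 3 to compound 4 (within the scatter), the first step in this set that isolates a single change, here 2-(ethoxycarbonyl)ethyl to 2-(methylcarbamoyl)ethyl. Compound 3 gives 0% and compound 4 gives 0%, so exchanging the ester for this amide, which adds a hydrogen-bond donor, does not lift the maximal response at this position, and a fall could not be seen from a value of nil. Nothing measured on these compounds offers an explanation for this result.

The compounds shown leave open whether a free carboxylic acid, a dimethylamino group or a longer chain on the amide nitrogen would give a response at this carbonyl carbon. They also leave open whether a shorter chain in place of 2-(methylcarbamoyl)ethyl would do so.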